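Swapping the ketone aryl group on a thiophene kinase scaffold

A few compounds are considered here, and "the series" means these few. Any claim that something is new, unique, unknown or untested is made for them only; others in the source may bear on it.

Compound 1 `COc1ccc(C(=O)c2sc(NC(C)C)c(C#N)c2N)cc1OC`: 1770 nM
Compound 2 `CC(C)Nc1sc(C(=O)c2ccncc2)c(N)c1C#N`: > 5000 nM

Two compounds sharing the same core were measured in an assay for inhibition of Maternal embryonic leucine zipper kinase (Homo sapiens), read by ADP-Glo, with a stated time of 0.5 h; a lower number here means a stronger inhibitor, a higher number a weaker inhibitor. Compound 1 gives a numerical value. Compound 2, by contrast, sits at the limit of > 5000 nM in this assay, at which 1 of the 2 values shown sits, a limit of the assay rather than a measured number, so its true potency is known only to lie beyond that cut-off.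

Compound 3 `Cc1ccc(C(=O)c2sc(NC(C)C)c(C#N)c2N)s1` is the next member of the series and has not yet been measured. It differs from compound 2 in one place: 5-methylthiophen-2-yl in place of pyridin-4-yl on a carbonyl carbon.

For the measured compounds named here, with no measured pair isolating this particular change, the expectation rests on compound 1, whose reading of 1770 nM shows that a different group on the carbonyl carbon does return a number in this assay. The step from compound 2 to compound 3 is therefore expected to be an at least 1.6-fold lower number from compound 2 to compound 3 (0.22 log units; that floor lies within the scatter), toward stronger inhibition. Compound 3 is estimated at 3000 nM, with a plausible range from 800 nM to 10000 nM.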

Compound 3, half-maximal inhibitory concentration: 494 nM
The estimate for compound 3 lay 6.1-fold (0.78 log units) above the measured number; measured number outside the range, below it.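

On the carbonyl carbon, 5-methylthiophen-2-yl in place of pyridin-4-yl gives an at least 10-fold lower number from compound 2 to compound 3 (1.00 log units; beyond the scatter) in this assay, which shows that the choice of ring at this position can move the reading by a wide margin. The two groups have the same counts of heavy atoms, hydrogen-bond donors and hydrogen-bond acceptors and carry no net charge, so those counts do not separate them; they differ in ring size and in sulfur against nitrogen. The size of the step is only a floor, since compound 2 stands at a limit of the assay and not at a number: the limit of > 5000 nM in this assay, at which 1 of the 3 values shown sits.

On these data alone, it remains open whether the ring or its methyl accounts for the step. A plain thiophen-2-yl group on the carbonyl carbon would separate the two, and the effect of a chlorine or an ethyl group in place of that methyl is also unknown.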